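A few compounds are considered here, and "the series" means these few. Any claim that something is new, unique, unknown or untested is made for them only; others in the source may bear on it.

Values in a functional assay on MCF7 cells (Homo sapiens) for antiproliferative activity, read by MTT assay, with a stated time of 72 h; on this read-out higher numbers stand for weaker inhibition and lower numbers for stronger inhibition:
- compound 1 `Nc1nc(N)c2cc(CSC(=S)N3CCN(c4ccc(O)cc4)CC3)ccc2n1`: 5090 nM
- compound 2 `Nc1nc(N)c2cc(CSC(=S)N3CCN(c4ccccc4Cl)CC3)ccc2n1`: 3190 nM

Compound 2 and compound 1 lie within the scatter of each other, so the two values mark one level and no order. The next compound to be measured is compound 3 `Nc1nc(N)c2cc(CSC(=S)N3CCN(c4ccc(F)cc4F)CC3)ccc2n1`, where 2,4-difluorophenyl takes the place of 2-chlorophenyl on an amine nitrogen in a ring (2,4-difluorophenyl in place of 2-chlorophenyl on an amine nitrogen in a ring). For the measured compounds named here, one measured step bears on this change: a 1.6-fold lower number from compound 1 to compound 2 (0.20 log units; within the scatter), a swap of the group at that same place, and it stayed within the scatter. A single step is thin evidence, but it gives no ground to expect a shift beyond the scatter in this assay, in either direction. The expected step is a 1.1-fold higher number from compound 2 to compound 3 (0.04 log units; within the scatter), which is no shift beyond the scatter. For compound 3 the estimated value is 3500 nM, with an expected range of 1500 nM to 8000 nM.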

Compound 3, half-maximal inhibitory concentration: 3670 nM
For compound 3 the middle estimate is 1.0-fold (0.02 log units) below the measured one, and the stated range covers the measured number.
By their numbers in this assay, from the lowest: compounds 2, 3 and 1 (each within the scatter of the next).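

Across this assay, a third group on the amine nitrogen in the ring, 2,4-difluorophenyl, stays on the same level as the other two (a 1.2-fold higher number from compound 2 to compound 3 (0.06 log units; within the scatter); a 1.4-fold lower number from compound 1 to compound 3 (0.14 log units; within the scatter)), and both steps lie within the scatter. Two fluorine atoms on the phenyl ring in place of one chlorine, or in place of the hydroxyl of 4-hydroxyphenyl, therefore bring no readable shift, so compounds 1, 2 and 3 mark one level and no order. No measurement at hand bears on why this level holds.

From the compounds shown here alone, all three groups at this place are substituted phenyl rings, so it stays open whether a benzyl, a cyclohexyl or a simple methyl there would leave that level. Also open, going by these compounds, is whether a carboxylic acid or an amine on the phenyl ring would do so.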